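A few compounds are considered here, and "the series" means these few. Any claim that something is new, unique, unknown or untested is made for them only; others in the source may bear on it.

Compound 1 `Cc1cc(C#N)cc(C)c1Oc1ccc(N)c(Nc2ccc(C#N)cc2)n1` is the starting point, measured in an ADME assay on MT2 cells (Homo sapiens) for cytotoxicity, read by XTT assay, with a stated time of 4 days; on this read-out lower numbers stand for higher toxicity in this test and higher numbers for lower toxicity in this test. In that test compound 1 gives > 100000 nM, which is a limit of the assay and not a number. A second compound has also been measured, compound 2 `CC(=O)/C=C/c1cc(C)c(Oc2cc(Nc3ccc(C#N)cc3)c([N+](=O)[O-])cc2[N+](=O)[O-])c(C)c1`. In this assay compound 2 gives > 100000 nM, which is also a limit. Compound 1 therefore stands with the only other compound shown, and the evidence so far amounts to this: the limit of > 100000 nM in this assay, at which 2 of the 2 values shown sit.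

Compound 3 `C=CCc1cc(C)c(Oc2ccc(N)c(Nc3ccc(C#N)cc3)n2)c(C)c1` keeps the core of compound 1 and changes one group: allyl in place of cyano on an aromatic carbon. In words, this is allyl in place of cyano on an aromatic carbon, meta to two methyl groups and para to a large group. Among the compounds with values here, no measured pair shows what such a swap does in this assay, so any forecast here is uncertain. A modest move toward lower numbers is expected, and the result may well stay at the limit. The expected change is an at least 1.6-fold lower number from compound 1 to compound 3 (0.22 log units; that floor lies within the scatter). For compound 3 the estimated value is 60000 nM, with an expected range from 15000 nM to 100000 nM.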

Compound 3, half-maximal cytotoxic concentration: 14000 nM
Estimate against measurement, compound 3: 4.3-fold (0.63 log units) above; measured number outside the range, below it.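

Putting allyl in place of cyano at this position, meta to two methyl groups and para to a large group, moves the read-out in this assay by an at least 7.1-fold lower number from compound 1 to compound 3 (0.85 log units; beyond the scatter). For compound 1, > 100000 nM is a limit of the assay and not a number. This single change on the shared core is therefore enough to bring a compound into the range where the assay gives an actual number, and compound 3 is the only one of the three shown that has such a number, while the other two stay at the limit: the limit of > 100000 nM in this assay, at which 2 of the 3 values shown sit.

One swap cannot separate what comes from adding allyl and what comes from losing cyano, so the result does not say which part of the change matters, or whether the double bond of allyl plays any part. On these data alone, the effect of a propyl group, a longer chain, an amine or a carboxylic acid at this position stays open, as does whether allyl would lower the number in the same way on a different core.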